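The compounds below may be only part of what the source reports. "The series", "measured", "known", "first", "only" and "open" are said of these compounds alone.

Measured so far:
compound 1 `CCc1ccc(NC(=O)c2csc(Cc3c(Cl)cccc3Cl)n2)cc1`: 1450 nM
compound 2 `O=C(Nc1ccc(C(F)(F)F)nc1)c1csc(Cc2c(Cl)cccc2Cl)n1`: 130 nM

In an assay on CHO cells, read by calcium flux (a lower number here means a stronger inhibitor, a higher number a weaker inhibitor), compound 1 gives 1450 nM, the highest of the two numbers; compound 2 gives 130 nM, and the gap between the two is beyond the scatter. Compound 3 `O=C(Nc1ccccc1Br)c1csc(Cc2c(Cl)cccc2Cl)n1` differs from compound 1 in one place: 2-bromophenyl in place of 4-ethylphenyl on an amide-type nitrogen. Going by the values given here, no measured pair covers this change, so nothing sets its size. The step expected in this assay is a 1.2-fold higher number from compound 1 to compound 3 (0.09 log units; within the scatter), a slight weakening that need not clear the scatter. For compound 3 in this assay the estimate is 1800 nM, with a range of 500 nM to 6000 nM.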

Compound 3, half-maximal inhibitory concentration: > 4000 nM
Compound 3: only a limit was reported; the forecaster's own chance of this, stated with the estimate: 10%; middle value at least 2.2-fold (0.34 log units) from the limit.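

Compound 3 gives > 4000 nM in this assay, which is a limit of the assay and not a number. This is the only single-place step shown, and it makes clear that the group on the amide-type nitrogen matters: 2-bromophenyl in place of 4-ethylphenyl gives an at least 2.7-fold higher number from compound 1 to compound 3 (0.44 log units; beyond the scatter). The true size of that step stays unknown, and it is bounded only by the limit: the limit of > 4000 nM in this assay, at which 1 of the 3 values shown sits.

As far as these compounds go, it remains open whether the step follows the arrival of bromine or the departure of ethyl, which a plain phenyl on the same nitrogen would help to separate. From the compounds shown here alone, how an amine or a carboxylic acid on this ring would read in this assay is also open.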